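The source may report more compounds than this note shows. Statements on the series, on what has been measured and on what is new or still open speak of the compounds shown alone.

In a functional assay on Bel-7402 cells (Homo sapiens) for inhibition, read by MTT assay, with a stated time of 24 h, tested at 0.1 ug/mL (a lower number here means less inhibition of growth, a higher number more inhibition of growth at the concentration tested), compound 1 `O=C(O)CCCCC(CCSC(=O)c1ccccc1)SC(=O)c1ccccc1` gives 1.09%. Going by the values given here, compound 3 `CC(=O)SCCC(CCCCC(=O)Nc1ccc(Cl)cc1)SC(C)=O` gives 9.96%, and these two numbers lie within the usual scatter of each other, so compound 1 cannot be told apart from the only other compound with a number. Compound 2 `O=C(CCCCC(S)CCS)Nc1ccc(OC(F)(F)F)cc1` is reported as "not active" (no number reported), with no number attached.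

Compound 4 `O=C(CCCCC(CCSC(=O)c1ccccc1)SC(=O)c1ccccc1)Nc1ccccc1` has not yet been measured. It keeps the core of compound 1 and makes a single change: anilino in place of hydroxy on a carbonyl carbon. In words, this is anilino in place of hydroxy on a carbonyl carbon, which turns a carboxy group into a phenylcarbamoyl group. Among the compounds with values here, no two measured compounds differ in one place only, so no measured step can serve as a guide. Compound 3 also carries an amide rather than a carboxy group, but it differs elsewhere too, so its 9.96% is only a loose hint. The estimated a number 4.9 percentage points higher from compound 1 to compound 4 (within the scatter) is expected to stay within the scatter. For compound 4 the expected value is 6%, with an estimated range of 0% to 18%.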

Compound 4, percent growth inhibition at one concentration: "not active" (no number reported)
No number was reported for compound 4; there is nothing to compare the estimate with.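

Going by these compounds alone, compound 4 is reported without a number in this assay, so no step from compound 1 can be read. The compounds shown leave open whether anilino in place of hydroxy changes growth inhibition at all, and no evidence here bears on this result.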